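Imidazole for hydroxymethylpyridine: clearance outlook for compound 4

The source may hold more compounds than are shown below. What is called first, only, known or untested is meant among the compounds shown, and "the series" means these compounds.

Working notes on a set of four compounds sharing one core. Compound 1 `Cc1cc(-c2cnc(NCc3c(F)ccc4c3CCO4)c3cn[nH]c(=O)c23)n(C)n1` gives 24 mL.min-1.g-1 in an ADME assay on microsomes from liver (Homo sapiens) for metabolic stability, read by LC-MS, using NADPH, with stated times of 5 min and 30 min, tested at 1 uM; on this read-out lower numbers stand for slow clearance and higher numbers for fast clearance. Compound 2 `O=C1CCCN1c1cnc(NCc2c(F)ccc3c2CCO3)c2cn[nH]c(=O)c12` gives 23 mL.min-1.g-1, and compound 3 `Cc1nc(CO)ccc1-c1cnc(NCc2c(F)ccc3c2CCO3)c2cn[nH]c(=O)c12` gives 11 mL.min-1.g-1. Compound 3 stands lowest of the three, with a 2.1-fold lower number from compound 2 to compound 3 (0.32 log units; beyond the scatter) and a 2.2-fold lower number from compound 1 to compound 3 (0.34 log units; beyond the scatter), both modest steps beyond the scatter, while a 1.0-fold lower number from compound 1 to compound 2 (0.02 log units; within the scatter) shows the two earlier aryl groups on a par.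

Compound 4 `Cc1ncc(-c2cnc(NCc3c(F)ccc4c3CCO4)c3cn[nH]c(=O)c23)n1C` is not yet measured. It differs from compound 3 in one place: 1,2-dimethyl-1H-imidazol-5-yl in place of 6-(hydroxymethyl)-2-methylpyridin-3-yl on an aromatic carbon. The two steps that bear on this are those into compound 3, each a modest lowering when the 6-(hydroxymethyl)-2-methylpyridin-3-yl group came in. Compound 4 gives that group up for a 1,2-dimethyl-1H-imidazol-5-yl group, a five-membered aromatic ring with two hetero atoms, closer in kind to the 1,3-dimethyl-1H-pyrazol-5-yl of compound 1. The expected outcome is therefore a return toward the numbers of compounds 1 and 2, a modest rise of about a 1.6-fold higher number from compound 3 to compound 4 (0.21 log units; within the scatter), though a result within the scatter of compound 3 cannot be ruled out. Compound 4 is estimated at 18 mL.min-1.g-1, with a range from 9 mL.min-1.g-1 to 36 mL.min-1.g-1.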

Compound 4, intrinsic clearance in microsomes in the Homo sapiens assay: 10 mL.min-1.g-1
Compound 4: the middle estimate sits 1.8-fold (0.26 log units) above what was measured, within the range that was stated.
By their numbers in the Homo sapiens assay, from the lowest: compounds 4 and 3 (each within the scatter of the next); then compounds 2 and 1 (each within the scatter of the next).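

At this position on an aromatic carbon, the low clearance seen with compound 3 in the Homo sapiens assay does not depend on a hydroxymethyl group or a six-membered ring: with a 1.1-fold lower number from compound 3 to compound 4 (0.04 log units; within the scatter), the 1,2-dimethyl-1H-imidazol-5-yl group, which carries no hydrogen-bond donor, stands level with the 6-(hydroxymethyl)-2-methylpyridin-3-yl group. A five-membered aromatic ring with two hetero atoms does not by itself fix the number in the Homo sapiens assay, since the two dimethylated rings are separated by a 2.4-fold lower number from compound 1 to compound 4 (0.38 log units; beyond the scatter), while the 2-oxopyrrolidin-1-yl group stands apart from the imidazole by a 2.3-fold lower number from compound 2 to compound 4 (0.36 log units; beyond the scatter). In a physicochemical assay for lipophilicity, using the shake flask method, in phosphate buffer, measured as octanol-water partition, with a stated time of 30 min, at pH 7.4 (a lower number here means a more polar compound, a higher number a more lipophilic compound), compound 3 gives 2.4 and compound 4 gives 1.9, so this change shows a number 0.50 log units lower from compound 3 to compound 4 (beyond the scatter), a shift in distribution coefficient with no accompanying separation in clearance between the two compounds.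

The compounds shown leave open how much of the imidazole result rests on its two methyl groups, which a 1-methyl-1H-imidazol-5-yl group would test. They also leave open how clearance responds to an amine or a carboxylic acid carried on the ring at this position.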